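The source may report more compounds than this note shows. Statements on the series, on what has been measured and on what is new or still open speak of the compounds shown alone.

Compound 1 `C/C(=N\NC(=O)/C(C#N)=C/c1ccc(O)cc1)c1c(O)c2ccc(O)cc2oc1=O`: 6230 nM
Compound 2 `C/C(=N\NC(=O)/C(C#N)=C/c1ccc(Br)cc1)c1c(O)c2ccc(O)cc2oc1=O`: 11400 nM
Compound 3 `C/C(=N\NC(=O)/C(C#N)=C/c1ccc([N+](=O)[O-])cc1)c1c(O)c2ccc(O)cc2oc1=O`: 9640 nM

The three measured compounds share one core and differ only in the aryl group carried on the double-bonded chain carbon. In a functional assay on A549 cells (Homo sapiens) for cytotoxicity, read by MTT assay, with a stated time of 24 h (on this read-out higher numbers stand for weaker inhibition and lower numbers for stronger inhibition), compound 1 gives the lowest of the three numbers, but its companions sit close by: a 1.8-fold higher number from compound 1 to compound 2 (0.26 log units; within the scatter) and a 1.5-fold higher number from compound 1 to compound 3 (0.19 log units; within the scatter), while a 1.2-fold lower number from compound 2 to compound 3 (0.07 log units; within the scatter). Among the measured compounds shown here, no pair is separated beyond the scatter, so none of the three can be called stronger or weaker than another.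

Compound 4 `C/C(=N\NC(=O)/C(C#N)=C/c1ccccc1Cl)c1c(O)c2ccc(O)cc2oc1=O` differs from compound 1 in one place: 2-chlorophenyl in place of 4-hydroxyphenyl on a double-bonded chain carbon bound to a double-bonded chain carbon. The measured steps that bear on this are the two that remove the hydroxy of compound 1 in favour of another substituent, bromo in compound 2 and nitro in compound 3; both returned slightly higher numbers within the scatter. For the measured compounds named here, compound 4 likewise gives up the hydroxy and takes on a halogen, though in a 2-chlorophenyl that no measured compound carries, so that arrangement is untested here. A small upward step is therefore expected, a 1.4-fold higher number from compound 1 to compound 4 (0.16 log units; within the scatter), not beyond the scatter. Compound 4 is estimated at 9000 nM, with a range from 4000 nM to 20000 nM.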

Compound 4, half-maximal inhibitory concentration: 14200 nM
Compound 4: the middle estimate sits 1.6-fold (0.20 log units) below what was measured, and the stated range covers the measured number.
By their numbers in this assay, from the lowest: compounds 1, 3, 2 and 4 (each within the scatter of the next, the first and the last beyond it).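

In this assay, among the compounds shown here, exchanging 4-hydroxyphenyl for 2-chlorophenyl on a double-bonded chain carbon bound to a double-bonded chain carbon gives a 2.3-fold higher number from compound 1 to compound 4 (0.36 log units; beyond the scatter), the first step to pass beyond the scatter, so the aryl group at this position can shift the read-out, if only modestly. That separation holds only against compound 1: the 2-chlorophenyl group stays within the scatter of the 4-nitrophenyl and 4-bromophenyl groups, with a 1.5-fold higher number from compound 3 to compound 4 (0.17 log units; within the scatter) and a 1.2-fold higher number from compound 2 to compound 4 (0.10 log units; within the scatter), so compounds 2, 3 and 4 cannot be told apart from one another. No measurement shown here accounts for the step.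

The compounds shown leave open whether the step belongs to the chlorine itself or to the 2-chlorophenyl arrangement, a question that a 4-chlorophenyl group at the same position would address. Also open, on these data alone, is how an unsubstituted phenyl, or an aryl group carrying an amine or a carboxylic acid, would stand in this assay against compound 1.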